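The compounds below may be only part of what the source reports. "The series", "measured", "known", "first", "only" and "open" are said of these compounds alone.

Compound 2 `O=C(O)c1cnc2cc(OCCc3ccc(Br)cc3)ccc2c1O` sits at the strong end of the three compounds measured here: in an assay on isolated protein with malate dehydrogenase, cytoplasmic (Sus scrofa) as the target (a lower number here means a stronger inhibitor, a higher number a weaker inhibitor), compound 2 gives 91200 nM, while compound 1 `CN(C)c1ccc2c(O)c(C(=O)O)cnc2c1` gives 372000 nM and compound 3 `O=C(O)c1cnc2cc(O)ccc2c1O` gives 955000 nM. Compound 4 `O=C(O)c1cnc2cc(OCCc3ccccc3)ccc2c1O` differs from compound 2 only at the far end of the side chain: hydrogen in place of bromo on an aromatic carbon, para to a large group, so that the 4-bromophenyl becomes a phenyl. Among the compounds with values here, the one step measured, a 2.6-fold higher number from compound 1 to compound 3 (0.41 log units; beyond the scatter), concerns a different group on the shared core and does not bear on a change at the end of the side chain. Within the data shown here, no measured pair speaks to the loss of the bromo, so the expectation rests only on the size of the change, a single heavy atom at a remote position. Compound 4 is therefore expected to lie close to compound 2, with a step of a 1.6-fold higher number from compound 2 to compound 4 (0.22 log units; within the scatter) most likely, slightly toward a higher number. The estimate for compound 4 is 150000 nM, within a range from 60000 nM to 400000 nM.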

Compound 4, half-maximal inhibitory concentration: 155000 nM
Beside the measured number, compound 4's estimate is 1.0-fold (0.01 log units) below it; the measured number falls inside the stated range.
By their numbers in this assay, from the lowest: compounds 2 and 4 (each within the scatter of the next); then compound 1; then compound 3.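

Within the data shown here, this pair is the first to test the far end of the side chain, as the only earlier step concerned a different group on the shared core. In this assay, the step of a 1.7-fold higher number from compound 2 to compound 4 (0.23 log units; within the scatter) shows that the 4-bromophenyl and the phenyl cannot be told apart, so the bromo, para to a large group, is not needed for a number in this range. Nothing available bears on why this exchange leaves the number within the scatter. Going by these compounds, whether an amine or a carboxylic acid on the same aromatic carbon would move the number beyond the scatter remains open. So does the effect of a longer chain leading to the phenyl, and of a chlorine or a methoxy group in place of the bromo.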